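This account rests on a few compounds, and the source may have more. Where it says the series, first, only, none or still open, it means among the compounds named here.

Compound 2 `CC(C)C(=O)Nc1cc(Oc2ccc(Nc3nccc4[nH]cc(-c5ccc(F)cc5)c(=O)c34)cc2F)ccn1` stands highest of the two numbers in a functional assay on HT-29 cells (Homo sapiens) for antiproliferative activity, read by MTT assay, with a stated time of 72 h, tested at 10 uM (a higher number here means more inhibition at the concentration tested (going by the name of the read-out), a lower number less inhibition), giving 83.4%; compound 1 `O=C(Nc1cc(Oc2ccc(Nc3nccc4[nH]cc(-c5ccc(F)cc5)c(=O)c34)cc2F)ccn1)C1CCC1` gives 46%. Among the measured compounds shown here, the only measured step, a number 37.4 percentage points higher from compound 1 to compound 2 (beyond the scatter), went with isopropyl in place of cyclobutyl on a carbonyl carbon, so a change at this acyl position can move the number widely. Compound 3 `CCC(=O)Nc1cc(Oc2ccc(Nc3nccc4[nH]cc(-c5ccc(F)cc5)c(=O)c34)cc2F)ccn1` differs from compound 2 by hydrogen in place of methyl on a saturated chain carbon bound to a carbonyl carbon and a saturated chain carbon, cutting the same chain further. That step bears on it only indirectly, and the direction for a shorter chain is uncertain. A modest downward step or none beyond the scatter is expected, a number 11.4 percentage points lower from compound 2 to compound 3 (beyond the scatter). Compound 3 is estimated at 72%, range 48% to 92%.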

Compound 3, a percentage reported as inhibition, at one concentration (the size of the read-out at that concentration, not a potency): 68.7%
Beside the measured number, compound 3's estimate is 3.3 percentage points above it, within the range that was stated.
By their numbers in this assay, from the lowest: compound 1; then compound 3; then compound 2.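

Isopropyl to ethyl gives a number 14.7 percentage points lower from compound 2 to compound 3 (beyond the scatter), so this acyl position responds to the loss of a single methyl, though less than to the cyclobutyl to isopropyl change. Ethyl in place of cyclobutyl gives a number 22.7 percentage points higher from compound 1 to compound 3 (beyond the scatter), which places ethyl between the other two groups and shows that compound 1 is the low point of the three. No measurement on hand explains this order.

The compounds shown leave open how a longer chain, such as butanoyl, or an amine on the acyl chain would read here. Going by these compounds, whether acetyl continues the downward step from isopropyl to ethyl also remains open.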